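The source may report more compounds than this note shows. Statements on the series, on what has been measured and on what is new or still open speak of the compounds shown alone.

Measured so far: compound 1 `CCCNC(=O)Oc1cccc(C(=O)c2nc3ccccc3o2)c1` with 109 nM in an assay (strain Wistar) for inhibition of Fatty-acid amide hydrolase 1 (Rattus norvegicus) (on this read-out lower numbers stand for stronger inhibition and higher numbers for weaker inhibition), and compound 2 `O=C(NC1CCCC1)Oc1cccc(C(=O)c2nc3ccccc3o2)c1` with 28 nM.

Compound 1 stands as the higher of the two numbers; the step of a 3.9-fold lower number from compound 1 to compound 2 (0.59 log units; beyond the scatter) is modest but beyond the scatter. Compound 3 `Cc1cccc(CNC(=O)Oc2cccc(C(=O)c3nc4ccccc4o3)c2)c1` differs from compound 1 by 3-methylphenyl in place of ethyl on a saturated chain carbon bound to an amide-type nitrogen. Among the compounds with values here, only that one step bears on this change, and it went toward a lower number when a larger group replaced propyl on the amide-type nitrogen. A step of comparable size and direction is therefore expected, a 2.7-fold lower number from compound 1 to compound 3 (0.44 log units; beyond the scatter), though the ring type differs. Compound 3 is estimated at 40 nM, within 10 nM to 150 nM.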

Compound 3, half-maximal inhibitory concentration: 32 nM
Compound 3: middle estimate off by 1.3-fold (0.10 log units), on the high side; low and high end bracket the measured number.
By their numbers in this assay, from the lowest: compounds 2 and 3 (each within the scatter of the next); then compound 1.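

Replacing propyl with 3-methylbenzyl on the amide-type nitrogen gives a 3.4-fold lower number from compound 1 to compound 3 (0.53 log units; beyond the scatter) and so shows that a group carrying an aromatic ring at this place also goes with a lower number than propyl, as the saturated ring of compound 2 did. The two replacements cannot be told apart, since a 1.1-fold higher number from compound 2 to compound 3 (0.06 log units; within the scatter) stands as the step between them. Nothing measured here accounts for either step. As far as these compounds go, it remains open whether unsubstituted benzyl, a longer chain such as hexyl, or a benzyl ring bearing an amine or a carboxylic acid would give a similar number.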